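The compounds below may be only part of what the source reports. "The series", "measured", "known", "first", "only" and "open" are said of these compounds alone.

Measured in a functional assay on MCF7 cells (Homo sapiens) for cytotoxicity, read by MTT assay, with a stated time of 48 h; on this read-out lower numbers stand for stronger inhibition and higher numbers for weaker inhibition:
Compound 1 `CC(=NNC(=S)Nc1ccccc1[N+](=O)[O-])c1ccccn1` gives 5.7 nM
Compound 2 `C/C(=N\NC(=S)Nc1ccccc1[N+](=O)[O-])c1ccccn1` gives 5.7 nM

For the measured compounds named here, compound 1 stands level with compound 2 in this assay, and these two are the only measured compounds. They have the same atoms and bonds. Going by the values given here, the only measured step is no change at the digits printed from compound 1 to compound 2 (within the scatter), and all that separates the pair is the fact that one of compounds 1 and 2 is drawn with a defined configuration and the other without, at the place where they differ. That step therefore shows only that this difference in drawing leaves the value unchanged. It says nothing about replacing one group with another.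

Compound 3 `CC(=NNC(=S)Nc1ccccc1I)c1ccccn1` keeps the core of compound 1 but has iodo in place of nitro on an aromatic carbon, ortho to a large group (iodo in place of nitro on an aromatic carbon). Among the compounds with values here, no measured step covers such an exchange, so the data give no direction and no size for it. The working expectation is therefore a value close to that of compound 1, with a wide range on either side.

The expected 1.4-fold higher number from compound 1 to compound 3 (0.15 log units; within the scatter) stays within the usual scatter, although this is only a weakly supported estimate.

For compound 3 the estimated value is 8 nM, with an expected range from 1.5 nM to 40 nM.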

Compound 3, half-maximal inhibitory concentration: 4.1 nM
The estimate for compound 3 lay 2.0-fold (0.29 log units) above the measured number; low and high end bracket the measured number.
By their numbers in this assay, from the lowest: compounds 3, 1 and 2 (each within the scatter of the next).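

In this assay, for the compounds shown here, this is the first real exchange of one group for another at this place on the aromatic ring, ortho to a large group: iodo replaces nitro, giving a 1.4-fold lower number from compound 1 to compound 3 (0.14 log units; within the scatter). The earlier pair differed only in how a double bond was drawn, whereas here the two compounds differ in substance: a nitro group of three heavy atoms with two hydrogen-bond acceptors gives way to a single iodine atom with no hydrogen-bond acceptors, yet the values stay level, so in this pair neither the nitro group nor its acceptors are needed for a value of this size. Nothing measured here explains why the two groups give matching values, since the available information concerns only how compounds 1 and 2 are drawn.

The two groups shown cannot tell whether any group at this place would give a similar value, or whether an amine, a carboxylic acid or a longer chain there would shift the number beyond the usual scatter. On these data alone, it also remains open whether iodo and nitro would stay level at another place on the ring or in a different cell line.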